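From Propyl to 2-Hydroxyethyl on the Sulfonamide Nitrogen

The source may report more compounds than this note shows. Statements on the series, on what has been measured and on what is new or still open speak of the compounds shown alone.

Within the data shown here, compound 1 (`CCCNS(=O)(=O)c1ccc(Nc2ncc3c(n2)N(C2CCCC2)[C@H](CC)C(=O)N3C)cc1`) gives 2100 nM in a functional assay on NCI-H1975 cells (Homo sapiens) for antiproliferative activity, read by CCK-8 assay, with a stated time of 72 h (a higher number here means a weaker inhibitor of growth, a lower number a stronger inhibitor of growth), and holds the higher of the two numbers so far, while compound 2 (`CCCCNC(=O)c1ccc2c(ccn2-c2ncc3c(n2)N(C2CCCC2)[C@H](CC)C(=O)N3C)c1`) gives 990 nM as the lower one. Compound 3 (`CC[C@@H]1C(=O)N(C)c2cnc(Nc3ccc(S(=O)(=O)NCCO)cc3)nc2N1C1CCCC1`) departs from compound 1 by hydroxy in place of methyl on a saturated chain carbon, two bonds along the chain from a sulfonamide nitrogen with hydroxy in place of methyl on a saturated chain carbon, two bonds along the chain from a sulfonamide nitrogen. Among the measured compounds shown here, no measured pair shows this change, so no step beyond the scatter is expected in this assay. The estimate amounts to a 1.2-fold higher number from compound 1 to compound 3 (0.09 log units; within the scatter) and stays within that scatter. Compound 3 is expected at 2600 nM (estimated range 900 nM to 7500 nM).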

Compound 3, concentration for 50% growth inhibition: 2100 nM
Estimate against measurement, compound 3: 1.2-fold (0.09 log units) above, within the range that was stated.
By their numbers in this assay, from the lowest: compound 2; then compounds 1 and 3 (each within the scatter of the next).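

In this assay, among these compounds, hydroxy in place of methyl on a saturated chain carbon, two bonds along the chain from a sulfonamide nitrogen, shows no change at the digits printed from compound 1 to compound 3 (within the scatter) and so gives the first reading of this change, which no earlier pair offered. At this place, the entering hydrogen-bond donor and acceptor leave the number within the scatter. Nothing available accounts for this result. On these data alone, whether an amine, a carboxylic acid or a longer chain ending in hydroxy would read the same here stays open.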